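Lengthening an Amine Side Chain: Compound 2 to Compound 3

This account rests on a few compounds, and the source may have more. Where it says the series, first, only, none or still open, it means among the compounds named here.

Compound 2 `CN(C)CCCOc1c(OCc2ccccc2)cc(O)c2c(=O)cc(-c3ccccc3)oc12` was tested in a functional assay on B16 cells (Mus musculus) for cytotoxicity, read by MTT assay, with a stated time of 72 h (on this read-out lower numbers stand for stronger inhibition and higher numbers for weaker inhibition), and gives 5420 nM. Compound 1 `COc1c(OCCCCN2CCN(C)CC2)cc(O)c2c(=O)cc(-c3ccc([N+](=O)[O-])cc3)oc12` gives 2890 nM in this assay; the two numbers lie within the usual scatter of each other, so neither compound can be called the stronger one. Compound 3 `CN(C)CCCCOc1c(OCc2ccccc2)cc(O)c2c(=O)cc(-c3ccccc3)oc12` has not yet been measured. It differs from compound 2 by (dimethylamino)methyl in place of dimethylamino on a saturated chain carbon, three bonds along the chain from an oxygen on an aromatic ring. For the measured compounds named here, no measured pair shows this kind of change, so only a small step is expected, in no clear direction and not beyond the scatter: a 1.2-fold lower number from compound 2 to compound 3 (0.08 log units; within the scatter) in this assay. Compound 3 is therefore estimated at 4500 nM, with a range from 2000 nM to 12000 nM.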

Compound 3, half-maximal inhibitory concentration: 3220 nM
The estimate for compound 3 lay 1.4-fold (0.15 log units) above the measured number, within the range that was stated.
By their numbers in this assay, from the lowest: compounds 1, 3 and 2 (each within the scatter of the next).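

Adding one carbon to the chain, with (dimethylamino)methyl in place of dimethylamino, gives in this assay the first step read between two compounds that differ in one place: a 1.7-fold lower number from compound 2 to compound 3 (0.23 log units; within the scatter) is the result. With this shared core, the chain can therefore take this extra carbon with no change that can be told apart from the scatter. Nothing available explains this result. This single pair cannot show a trend with chain length. A longer chain, or a morpholine at the chain end in place of the dimethylamino group, remains an open question on this core.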